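This account rests on a few compounds, and the source may have more. Where it says the series, first, only, none or still open, it means among the compounds named here.

Working notes on the series in an assay on HEK293 cells for displacement of a labelled ligand from Neuronal acetylcholine receptor; alpha3/beta4 (Homo sapiens); a higher number here means a weaker inhibitor, a lower number a stronger inhibitor.

Two compounds share the same core and differ only in the aryl group on the nitrogen. Compound 1 `Clc1cccc(Nc2ccc(N3CC4CC(C3)N4)cn2)c1` gives 4.8 nM in this assay, and compound 2 `Fc1ccc(Nc2ccc(N3CC4CC(C3)N4)cn2)cc1` gives 13 nM. Among the measured compounds shown here, compound 1 therefore stands with the lowest number of the two measured so far; the only measured step, a 2.7-fold higher number from compound 1 to compound 2 (0.43 log units; beyond the scatter), puts 4-fluorophenyl in place of 3-chlorophenyl and moves the number beyond the scatter, though only modestly.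

Compound 3 `Clc1ccc(Nc2ccc(N3CC4CC(C3)N4)cn2)cc1Cl` is not yet measured in this assay. It differs from compound 1 by chloro in place of hydrogen on an aromatic carbon; the new chloro sits on an aromatic carbon of the six-membered carbon ring, ortho to the chloro group already present and para to the large group. For the measured compounds named here, no measured step adds a group to the aryl ring while keeping the 3-chloro in place, so the step from compound 1 to compound 2 bears on it only indirectly: it shows that changes to the aryl substitution shift this assay by modest amounts, not by large ones. A step from compound 1 to compound 3 of similar or smaller size is expected, in either direction or none beyond the scatter, estimated as a 1.0-fold higher number from compound 1 to compound 3 (0.02 log units; within the scatter). Compound 3 is therefore expected to give about 5 nM in this assay, within a range of 2 nM to 15 nM.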

Compound 3, inhibition constant: 40.9 nM
The estimate for compound 3 lay 8.2-fold (0.91 log units) below the measured number; the measured number lies above the stated range.
By their numbers in this assay, from the lowest: compound 1; then compound 2; then compound 3.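

In this assay, an 8.5-fold higher number from compound 1 to compound 3 (0.93 log units; beyond the scatter) shows that this aromatic carbon, ortho to a chloro group and para to a large group, is not a neutral place for substitution in the presence of the existing chloro group, since one added chlorine atom makes compound 3 the weaker inhibitor by a step beyond the scatter. This step appears larger than a 2.7-fold higher number from compound 1 to compound 2 (0.43 log units; beyond the scatter), so the earlier suggestion that changes to the aryl substitution produce only small shifts does not hold for this addition, even though the entering group has a single heavy atom, no hydrogen-bond donors or acceptors, and no net charge. No measurement shown here explains the rise in the number.

The compounds shown leave open whether the step belongs to chloro itself or to any group placed on this carbon, a question that fluoro, methyl, methoxy or an amine at the same position, with the existing chloro group kept, would address. They also leave open how the same chloro addition behaves when the existing chloro group is replaced by hydrogen.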